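Anilino in place of piperidinyl on the chloropurine core

The source may hold more compounds than are shown below. What is called first, only, known or untested is meant among the compounds shown, and "the series" means these compounds.

Measured compounds:
compound 1 `CC(C)n1cnc2c(Nc3ccccc3)nc(NCOCc3ccc(/C=C/C(=O)Nc4ccccc4N)cc3)nc21` — 2.53%
compound 2 `Cc1ccc(Nc2nc(Cl)nc3c2ncn3Cc2ccc(C(=O)Nc3ccccc3N)cc2)cc1` — 76.3%
compound 3 `CC1CCN(c2nc(Cl)nc3c2ncn3Cc2ccc(/C=C/C(=O)Nc3ccccc3N)cc2)CC1` — 4.24%

Three compounds have been run in a functional assay on HCT-116 cells (Homo sapiens) for antiproliferative activity, read by CCK-8 assay, with a stated time of 72 h, tested at 2 uM; on this read-out higher numbers stand for a stronger effect at the one concentration tested and lower numbers for a weaker effect. Compound 2 gives 76.3%, while compound 3 gives 4.24% and compound 1 gives 2.53%. Compound 3 thus sits second of the three numbers; its nearest neighbour is compound 1, whose value lies within the scatter of it, and its furthest is compound 2, which stands beyond the scatter above it.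

Compound 4 `Cc1ccc(Nc2nc(Cl)nc3c2ncn3Cc2ccc(/C=C/C(=O)Nc3ccccc3N)cc2)cc1` is not yet measured. It differs from compound 3 in one place: (4-methylphenyl)amino in place of 4-methylpiperidin-1-yl on an aromatic carbon. The group that enters is the same (4-methylphenyl)amino that compound 2 carries on its own core, and compound 2 gives 76.3% in this assay; compound 4 keeps the linker of compound 3, which gives 4.24%. Among the measured compounds shown here, no measured pair shows this exact change, so the size of the step is uncertain, but a rise is expected because compound 2 gives 76.3%. The expected step is a number 50.8 percentage points higher from compound 3 to compound 4 (beyond the scatter). Compound 4 is estimated at 55%, with a range from 20% to 85%.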

Compound 4, a percentage reported as inhibition, at one concentration (the size of the read-out at that concentration, not a potency): 0.27%
Compound 4: middle estimate off by 54.7 percentage points, on the high side; measured number outside the range, below it.
By their numbers in this assay, from the lowest: compounds 4, 1 and 3 (each within the scatter of the next); then compound 2.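

In this assay, putting (4-methylphenyl)amino in place of 4-methylpiperidin-1-yl on this aromatic carbon gives a number 4 percentage points lower from compound 3 to compound 4 (within the scatter), so with the ethenyl-containing group kept, the two groups at this position are not told apart. The large difference appears at the other place instead: changing (2-aminophenyl)carbamoyl to 2-((2-aminophenyl)carbamoyl)ethenyl on an aromatic carbon gives a number 76 percentage points lower from compound 2 to compound 4 (beyond the scatter), which shows that the (4-methylphenyl)amino group of compound 2 does not carry the high number on its own. Nothing available here explains this difference between the two groups.

The compounds shown leave open whether 4-methylpiperidin-1-yl on this aromatic carbon would hold up alongside the (2-aminophenyl)carbamoyl of compound 2, and whether a morpholin-4-yl group or a simple primary amine there would behave like either group tested. They also leave open whether a longer saturated carbon chain in place of the ethenyl part would give numbers like those of compound 2 or like those of compound 4.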